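Adding a Second Chloro Group to the Core of Compound 1

The compounds below may be only part of what the source reports. "The series", "measured", "known", "first", "only" and "open" are said of these compounds alone.

Compound 1 `ClCc1ccc(Cn2cnc3c(Cl)ncnc32)cc1` is examined in a functional assay on LOX IMVI cells (Homo sapiens) for cytotoxicity, read by sulforhodamine B assay, with a stated time of 48 h; on this read-out higher numbers stand for lower toxicity in this test and lower numbers for higher toxicity in this test. In this assay compound 1 gives 13500 nM, the higher of the two numbers recorded here. Compound 2 `ClCc1ccc(Cn2cnc3nc(Cl)nc(Cl)c32)cc1` gives 6450 nM in this assay, a lower number than compound 1 by a margin beyond the usual scatter. Compound 3 `ClCc1ccc(Cn2cnc3c(Cl)nc(Cl)nc32)cc1` is related to compound 1 by chloro in place of hydrogen on an aromatic carbon. Among the measured compounds shown here, no measured pair shows that exact change, so its effect is uncertain; a modest move toward lower numbers is expected, a 1.8-fold lower number from compound 1 to compound 3 (0.26 log units; within the scatter), in keeping with the lower number of compound 2. Compound 3 is therefore estimated at 7500 nM in this assay, with a likely range of 3000 nM to 18000 nM.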

Compound 3, concentration lethal to 50% of the cells: 8320 nM
Compound 3: the middle estimate sits 1.1-fold (0.05 log units) below what was measured, within the range that was stated.
By their numbers in this assay, from the lowest: compounds 2, 3 and 1 (each within the scatter of the next, the first and the last beyond it).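

In this assay, among the compounds shown here, the first direct reading at this position, chloro in place of hydrogen on an aromatic carbon between two ring nitrogen atoms gives a 1.6-fold lower number from compound 1 to compound 3 (0.21 log units; within the scatter). A second chloro group is therefore accommodated here, but this single step cannot be told apart from repeat-measurement noise. No measured information accompanies this result that could account for it. The compounds shown leave open whether an amine or a methoxy group at this same position would give a step beyond the scatter.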